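The compounds below may be only part of what the source reports. "The series", "measured", "known", "first", "only" and "open" are said of these compounds alone.

Measured compounds in this series:
- compound 1 `O=C1OCc2cc(N(Cc3ccc(C4CCCCC4)cn3)C(=O)[C@H]3CCN3S(=O)(=O)c3c(F)c(F)c(F)c(F)c3F)ccc21`: 4600 nM
- compound 2 `CC(C)(C)c1ccc(CN(C(=O)[C@H]2CCN2S(=O)(=O)c2c(F)c(F)c(F)c(F)c2F)c2ccc(C(=O)NO)cc2F)cc1`: "not determined" (no result reported)
- compound 3 `O=C(NO)c1ccc(N(Cc2ccc(C3CCCC3)cn2)C(=O)[C@H]2CCN2S(=O)(=O)c2c(F)c(F)c(F)c(F)c2F)c(F)c1`: "not determined" (no result reported)

Among the compounds with values here, in an ADME assay on MCF-10A cells (Homo sapiens) for cytotoxicity, with a stated time of 72 h (on this read-out lower numbers stand for an effect already at smaller amounts and higher numbers for an effect only at larger amounts of compound), compound 1 gives 4600 nM; this is the only number in hand, as compound 2 gives "not determined" (no result reported) and compound 3 gives "not determined" (no result reported) in this assay. Compound 1 therefore stands alone, with nothing to rank it against.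

The unmeasured compound 4 `O=C([C@H]1CCN1S(=O)(=O)c1c(F)c(F)c(F)c(F)c1F)N(Cc1ccc(C2CCCCC2)cn1)c1ccc2c(=O)[nH]cnc2c1` keeps the shared core of compound 1 and differs from it at one place: a group of 11 heavy atoms (8 carbon, 2 nitrogen, 1 oxygen; one six-membered aromatic ring of carbon only, one six-membered aromatic ring with 2 hetero atoms) in place of a group of 10 heavy atoms (8 carbon, 2 oxygen; one five-membered non-aromatic ring with 1 hetero atom, one six-membered aromatic ring of carbon only), on an amide-type nitrogen. The group that leaves holds one five-membered non-aromatic ring with 1 hetero atom fused to the six-membered aromatic ring of carbon only; the group that enters holds instead a six-membered aromatic ring with 2 hetero atoms and brings 1 hydrogen-bond donor.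

Within the data shown here, no step between two measured compounds is available to size such a change in this assay. With only compound 1 as anchor, the expected step of a 1.1-fold higher number from compound 1 to compound 4 (0.04 log units; within the scatter) is small, not beyond the usual scatter, in either direction. Compound 4 is thus estimated at 5000 nM in this assay, with a range of 1500 nM to 16000 nM.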

Compound 4, half-maximal effective concentration: 4000 nM
Compound 4: middle estimate off by 1.3-fold (0.10 log units), on the high side; the measured number falls inside the stated range.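

In this assay this position now has its first readable step: a 1.2-fold lower number from compound 1 to compound 4 (0.06 log units; within the scatter). On the amide-type nitrogen, the group with the six-membered aromatic ring with 2 hetero atoms and 1 hydrogen-bond donor can thus take the place of the group with the five-membered non-aromatic ring with 1 hetero atom without a change beyond the scatter, at least for this single pair on the shared core. Nothing measured on these compounds accounts for this result.

Still open, going by these compounds, is whether a group carrying a carboxylic acid or an amine on the same nitrogen would also stay within the scatter of compound 1. Equally open, on these data alone, is whether this exchange would read the same with a morpholine in place of the cyclohexyl group.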